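This account rests on a few compounds, and the source may have more. Where it says the series, first, only, none or still open, it means among the compounds named here.

Measured compounds:
- compound 1, `O=[N+]([O-])c1ccc(Oc2ccc(/C=N/NC(=S)Nc3ccc(Br)cc3)cc2)cc1`, 5.68
- compound 2, `Fc1ccc(Oc2ccc(/C=N/NC(=S)Nc3ccc(Br)cc3)cc2)cc1`, 5.82

Both compounds were examined in a physicochemical assay for lipophilicity, in phosphate buffer, measured as octanol-water partition, with a stated time of 24 h; on this read-out lower numbers stand for lower lipophilicity and higher numbers for higher lipophilicity. Compound 1 gives 5.68, the lower of the two numbers; its nearest neighbour is compound 2, and the step of a number 0.14 log units higher from compound 1 to compound 2 (within the scatter) lies within the scatter. Within the data shown here, that step, fluoro in place of nitro on an aromatic carbon, is the only measured change in this set, and it alters a different ring than the one considered next.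

The compound not yet measured is compound 3, `O=[N+]([O-])c1ccc(Oc2ccc(/C=N/NC(=S)Nc3ccc(Cl)cc3)cc2)cc1`. It differs from compound 1 in one place: chloro in place of bromo on an aromatic carbon. Among the measured compounds shown here, no measured step touches this ring, so the only guidance is that the one change measured so far, from compound 1 to compound 2, stayed within the scatter. An exchange of one halogen for another at the same place is expected to move the number in this assay by little, if anything, and if at all toward a lower value.

On that basis compound 3 is estimated at 5.5, with a range from 5.2 to 5.8. The step this implies, a number 0.18 log units lower from compound 1 to compound 3 (within the scatter), is expected to sit within the scatter.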

Compound 3, partition coefficient: 5.52
The estimate for compound 3 lay 0.02 log units below the measured number; the range from low to high includes it.
By their numbers in this assay, from the lowest: compounds 3, 1 and 2 (each within the scatter of the next).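

Chloro in place of bromo on an aromatic carbon, para to a large group, gives the first reading at this position in this assay, namely a number 0.16 log units lower from compound 1 to compound 3 (within the scatter) and so no change that can be told from the usual scatter. The exchange of these two halogens therefore joins the change at the other end of compound 1, a number 0.14 log units higher from compound 1 to compound 2 (within the scatter), so that single changes at two separate places in the core of compound 1 have now been read in this assay, and neither goes beyond the scatter. No measured evidence bears on this result, and the numbers alone offer no explanation for it.

The compounds shown carry only bromo and chloro at this position, so they leave open how far the number would move with an amine, a carboxylic acid or a longer chain in that place. They also leave open whether fluoro in place of nitro and chloro in place of bromo, taken together in a single compound, would still stay within the scatter of compound 1.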